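Series notes: methoxy addition on the anilino ring

The compounds below may be only part of what the source reports. "The series", "measured", "known", "first", "only" and "open" are said of these compounds alone.

The series shares one core bearing a (2-methoxyphenyl)amino group in compound 1 `COc1ccccc1Nc1nc(SCc2ccc(C(F)(F)F)cc2)nc2ccccc12`. In a functional assay on MCF7 cells (Homo sapiens) for cytotoxicity, read by MTT assay, with a stated time of 72 h (a higher number here means a weaker inhibitor, a lower number a stronger inhibitor), compound 1 gives > 50000 nM, which is a limit of the assay rather than a number. Compound 1 therefore stands at the limit of > 50000 nM in this assay, at which 1 of the 2 values shown sits. Compound 2 `FC(F)(F)c1ccc(CSc2nc(Nc3ccc(Cl)cc3)c3ccccc3n2)cc1` carries 4-chlorophenyl on the same nitrogen and gives 21500 nM in this assay, so that an at least 2.3-fold lower number from compound 1 to compound 2 (0.36 log units; beyond the scatter).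

The next compound, compound 3 `COc1ccc(Nc2nc(SCc3ccc(C(F)(F)F)cc3)nc3ccccc23)c(OC)c1`, differs from compound 1 by methoxy in place of hydrogen on an aromatic carbon; cut one bond further out this is 2-methoxyphenyl to 2,4-dimethoxyphenyl. Among the measured compounds shown here, the only measured step concerns an exchange of the whole aryl group rather than an added methoxy, so it bears only loosely on this change, and it was a modest step that started from a limit. For the measured compounds named here, no measured step shows what an added methoxy does here, and compound 1 itself has no exact number. The step expected from this change is a number no higher from compound 1 to compound 3 (the limit leaves the size open), meaning no shift beyond the scatter. For compound 3 the estimated value in this assay is 50000 nM, within a range of 20000 nM to 150000 nM, with a substantial chance that only a limit is reported.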

Compound 3, half-maximal inhibitory concentration: > 50000 nM
Compound 3: no number, only a limit; the forecaster's own chance of this, stated with the estimate: 60%; the middle value lies on the limit itself.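

In this assay compound 3 gives > 50000 nM, which is a limit of the assay and not a number, so a second methoxy, para to a large group on the anilino ring, does not bring a measurable value within the range of this assay. The step from compound 1 cannot be read, as both ends are limits, and the added methoxy therefore has no size here. Among the compounds shown here, the new information comes from the exchange of the whole aryl group on the nitrogen, which gives an at least 2.3-fold higher number from compound 2 to compound 3 (0.36 log units; beyond the scatter), so 2,4-dimethoxyphenyl falls with 2-methoxyphenyl and 4-chlorophenyl in compound 2 remains the only group with an exact number: the limit of > 50000 nM in this assay, at which 2 of the 3 values shown sit.

The compounds shown do not separate the presence of the chlorine in compound 2 from the absence of any methoxy group, as compound 2 and compound 3 differ in the whole aryl group. Plain phenyl, 4-methoxyphenyl and 4-aminophenyl on the same nitrogen remain open, as does whether any group there reaches a value well clear of the limit.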